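A few compounds are considered here, and "the series" means these few. Any claim that something is new, unique, unknown or untested is made for them only; others in the source may bear on it.

Working notes on the series. Three measured compounds share one core and differ only in the group attached to it. Compound 1 `O=C(O)c1ccccc1-c1ccc(CCc2ncc(C3CCCCC3)[nH]2)cc1` carries cyclohexyl there; in an in vitro functional assay on cells for agonist activity at Bombesin receptor subtype-3 (Homo sapiens), read by luminescence and calcium flux (on this read-out higher numbers stand for an effect only at larger amounts of compound and lower numbers for an effect already at smaller amounts), compound 1 gives 375 nM. Compound 2 `O=C(O)c1ccccc1-c1ccc(CCc2ncc(CC3CCOCC3)[nH]2)cc1` carries (oxan-4-yl)methyl; in this assay compound 2 gives 338 nM. The step of a 1.1-fold lower number from compound 1 to compound 2 (0.05 log units; within the scatter) lies within the scatter, so these two read alike. Compound 3 `N#Cc1ccccc1Cc1cnc(CCc2ccc(-c3ccccc3C(=O)O)cc2)[nH]1` carries 2-cyanobenzyl; in this assay compound 3 gives 5480 nM, the highest of the three numbers, with both steps beyond the scatter: a 15-fold higher number from compound 1 to compound 3 (1.16 log units; beyond the scatter) and a 16-fold higher number from compound 2 to compound 3 (1.21 log units; beyond the scatter).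

Compound 4 `O=C(O)c1ccccc1-c1ccc(CCc2ncc(Cc3ccccc3)[nH]2)cc1` is the next member: hydrogen in place of cyano on an aromatic carbon, which read one bond further out is 2-cyanobenzyl to benzyl. Within the data shown here, no measured step removes a nitrile, so none bears directly on this change. The two large steps into compound 3 only show that the nitrile-bearing benzyl stands well apart from the saturated groups of compounds 1 and 2; whether the nitrile alone carries that gap, or the aromatic ring does, the data do not show. With that uncertainty, a moderate move back toward the lower numbers is expected, a step of a 2.7-fold lower number from compound 3 to compound 4 (0.44 log units; beyond the scatter) that is estimated rather than grounded. Compound 4 is estimated at 2000 nM, expected within 500 nM to 8000 nM.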

Compound 4, half-maximal effective concentration: 205 nM
Beside the measured number, compound 4's estimate is 9.8-fold (0.99 log units) above it; the whole stated range lies above it.
By their numbers in this assay, from the lowest: compounds 4, 2 and 1 (each within the scatter of the next); then compound 3.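

In this assay the change from 2-cyanobenzyl to benzyl is large (a 27-fold lower number from compound 3 to compound 4 (1.43 log units; beyond the scatter)), so the gap that set compound 3 apart goes with the nitrile on this aromatic carbon and not with the aromatic ring itself. Benzyl also reads alike with the two saturated groups (a 1.6-fold lower number from compound 2 to compound 4 (0.22 log units; within the scatter); a 1.8-fold lower number from compound 1 to compound 4 (0.26 log units; within the scatter)), both steps within the scatter, so cyclohexyl, (oxan-4-yl)methyl and benzyl are not told apart at this position on the shared core, and an aromatic ring is tolerated there as well as a saturated one. Nothing at hand gives a reason for the large step on losing the nitrile.

Still open, on these data alone, is whether a fluorine, a methoxy group or an amine in place of cyano on this aromatic carbon would read like the nitrile or like hydrogen, which would show whether the step belongs to the nitrile alone or to any group there. Also open, as far as these compounds go, is whether the same step appears when the nitrile sits on a longer chain, as in 2-cyanophenethyl in place of 2-cyanobenzyl.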